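A few compounds are considered here, and "the series" means these few. Any claim that something is new, unique, unknown or untested is made for them only; others in the source may bear on it.

Measured in a functional assay on MCF7 cells (Homo sapiens) for antiproliferative activity, read by MTT assay, with stated times of 24 h and 72 h; on this read-out higher numbers stand for weaker inhibition and lower numbers for stronger inhibition:
- compound 1 `COc1cc([C@@H]2[C@H](Oc3ccccc3)C(=O)N2c2cc(OC)c(OC)c(OC)c2)cc(OC)c1OC` gives 29000 nM
- compound 2 `COc1cc(N2C(=O)[C@@H](Oc3ccccc3)[C@H]2c2cc(O)c(OC)c([N+](=O)[O-])c2)cc(OC)c1OC` gives 69000 nM
- compound 3 `COc1cc([N+](=O)[O-])c([C@@H]2[C@H](Oc3ccccc3)C(=O)N2c2cc(OC)c(OC)c(OC)c2)cc1O` gives 59000 nM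

Compound 3 sits on the high side of these numbers, with a 2.0-fold higher number from compound 1 to compound 3 (0.31 log units; beyond the scatter) and a 1.2-fold lower number from compound 2 to compound 3 (0.07 log units; within the scatter). Compound 4 `COc1ccc([C@@H]2[C@H](Oc3ccccc3)C(=O)N2c2cc(OC)c(OC)c(OC)c2)cc1N` replaces the nitro-bearing ring on the saturated ring carbon with 3-amino-4-methoxyphenyl, which is a group of 9 heavy atoms (7 carbon, 1 nitrogen, 1 oxygen; one six-membered aromatic ring of carbon only) in place of a group of 12 heavy atoms (7 carbon, 1 nitrogen, 4 oxygen; one six-membered aromatic ring of carbon only), on a saturated ring carbon. Within the data shown here, compound 1 carries no nitro group either, and the steps that bear on this change were both modest: a 2.4-fold higher number from compound 1 to compound 2 (0.38 log units; beyond the scatter) and a 2.0-fold higher number from compound 1 to compound 3 (0.31 log units; beyond the scatter). Among the measured compounds shown here, a step to a lower number is therefore expected, but no measured compound carries an amino group, so the uncertainty is wide. The expected change is a 7.4-fold lower number from compound 3 to compound 4 (0.87 log units; beyond the scatter). Compound 4 is estimated at 8000 nM, with an expected range from 600 nM to 45000 nM.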

Compound 4, half-maximal inhibitory concentration: 12200 nM
For compound 4 the middle estimate is 1.5-fold (0.18 log units) below the measured one; measured number inside the range.
By their numbers in this assay, from the lowest: compound 4; then compound 1; then compounds 3 and 2 (each within the scatter of the next).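

In this assay the steps of a 4.8-fold lower number from compound 3 to compound 4 (0.68 log units; beyond the scatter) and a 5.7-fold lower number from compound 2 to compound 4 (0.75 log units; beyond the scatter) and also a 2.4-fold lower number from compound 1 to compound 4 (0.38 log units; beyond the scatter) make 3-amino-4-methoxyphenyl the group with the lowest number at this saturated ring carbon. Among these compounds, the earlier compounds showed only higher numbers on leaving 3,4,5-trimethoxyphenyl, so this is the first replacement that lowers the number. Nothing available accounts for this gain.

Several features of the ring change together here, so the share of the amino group alone stays open. On these data alone, whether an acetamide or a dimethylamino group in its place would keep the lower number also stays open.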